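Ethoxy for methoxy(methyl)amino on the carbonyl of compound 2

A few compounds are considered here, and "the series" means these few. Any claim that something is new, unique, unknown or untested is made for them only; others in the source may bear on it.

Two nucleoside ureas were tested in a functional assay on CAKI-1 cells (Homo sapiens) for antiproliferative activity; a lower number here means a stronger inhibitor of growth, a higher number a weaker inhibitor of growth. Compound 1 `CCOC(=O)C[C@H]1[C@@H](O[Si](C)(C)C(C)(C)C)[C@H](n2cnc3c(NC(=O)Nc4ccccc4)ncnc32)O[C@@H]1COC(=O)NC` gives 3.72 nM. Compound 2 `CNC(=O)NC[C@H]1O[C@@H](n2cnc3c(NC(=O)Nc4ccccc4)ncnc32)[C@H](O[Si](C)(C)C(C)(C)C)[C@@H]1CC(=O)N(C)OC` gives 53.8 nM, the higher of the two numbers, and its gap to compound 1 lies beyond the scatter. Compound 3 `CCOC(=O)C[C@H]1[C@@H](O[Si](C)(C)C(C)(C)C)[C@H](n2cnc3c(NC(=O)Nc4ccccc4)ncnc32)O[C@@H]1CNC(=O)NC` differs from compound 2 by ethoxy in place of methoxy(methyl)amino on a carbonyl carbon, bringing in the ethoxycarbonyl group that compound 1 carries. Because compound 1 gives 3.72 nM with that same group, a step downward is expected, a 4.5-fold lower number from compound 2 to compound 3 (0.65 log units; beyond the scatter). Compound 3 is therefore estimated at 12 nM in this assay, within 3.5 nM to 45 nM.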

Compound 3, concentration for 50% growth inhibition: 29.7 nM
Estimate against measurement, compound 3: 2.5-fold (0.39 log units) below; the measured number falls inside the stated range.
By their numbers in this assay, from the lowest: compound 1; then compounds 3 and 2 (each within the scatter of the next).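

In this assay, ethoxy in place of methoxy(methyl)amino on a carbonyl carbon gives a 1.8-fold lower number from compound 2 to compound 3 (0.26 log units; within the scatter), so this change alone does not reach the low number of compound 1. The step beyond the scatter lies at the other place: (methylcarbamoyl)amino in place of (methylcarbamoyl)oxy on a saturated chain carbon bound to a saturated ring carbon gives an 8.0-fold higher number from compound 1 to compound 3 (0.90 log units; beyond the scatter). No measurement shown explains either step.

On these data alone, whether a carboxylic acid or a primary amide on that carbonyl carbon would shift the number remains open. So does whether methoxy(methyl)amino would behave the same alongside the (methylcarbamoyl)oxy group.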